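Swapping methoxy for fluoro on a weak triazole analogue

A few compounds are considered here, and "the series" means these few. Any claim that something is new, unique, unknown or untested is made for them only; others in the source may bear on it.

Of the compounds shown here, two from this series have been tested in a functional assay on SW480 cells (Homo sapiens) for cytotoxicity, read by MTT assay, with a stated time of 4 days; a lower number here means a stronger inhibitor, a higher number a weaker inhibitor. Compound 1, `C=C1C(=O)[C@]23C[C@@]1(O)CC[C@H]2c1ccc(OS(=O)(=O)c2ccc(C)cc2)c(C)c1[C@@H]3Cn1cc(-c2ccccn2)nn1`, gives 1970 nM in this assay. Compound 2, `C=C1C[C@]23C[C@@]1(O)CC[C@H]2c1cc(Br)c(O)c(C)c1[C@@H]3Cn1cc(-c2ccc(OC)cc2)nn1`, did not reach a measurable number: its result in this assay is a limit, > 20000 nM, and compound 2 is one of the entries described by the limit of > 20000 nM in this assay, at which 1 of the 2 values shown sits. Compound 3, `C=C1C[C@]23C[C@@]1(O)CC[C@H]2c1cc(Br)c(O)c(C)c1[C@@H]3Cn1cc(-c2ccc(F)cc2)nn1`, has not yet been measured in this assay. It differs from compound 2 in one place: fluoro in place of methoxy on an aromatic carbon, the same difference reading as 4-methoxyphenyl to 4-fluorophenyl one bond further out. For the measured compounds named here, no pair of measured compounds in this set shows such a step, so its size cannot be read from the data. Since compound 2 sits at the limit of this assay, compound 3 is expected to stay weak as well, with an estimated step of a number no higher from compound 2 to compound 3 (the limit leaves the size open) and an estimated value of 20000 nM, in a range from 5000 nM to 60000 nM.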

Compound 3, half-maximal inhibitory concentration: > 20000 nM
Compound 3: no number, only a limit (the forecaster's own chance of this, stated with the estimate: 65%); the middle value sits exactly at the limit.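

Compound 2 and compound 3 each give only a limit of the assay, not a number, so no step between them can be read: the limit of > 20000 nM in this assay, at which 2 of the 3 values shown sit.

The compounds shown leave open whether 4-methoxyphenyl and 4-fluorophenyl differ at all in strength on this shared core, and by how much.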